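A few compounds are considered here, and "the series" means these few. Any claim that something is new, unique, unknown or untested is made for them only; others in the source may bear on it.

Compound 1 `O=c1cc(Cn2cc(CCCCl)nn2)c2ccc(O)cc2o1`: in a functional assay on CFPAC-1 cells (Homo sapiens) for inhibition, read by MTT assay, with a stated time of 72 h (on this read-out higher numbers stand for weaker inhibition and lower numbers for stronger inhibition), compound 1 gives 75800 nM.
Compound 2 `O=c1cc(Cn2cc(CCCCO)nn2)c2ccc(O)cc2o1`: in this assay compound 2 gives only a limit, > 100000 nM.

Going by the values given here, compound 2 thus stands at the ceiling of the assay, (the limit of > 100000 nM in this assay, at which 1 of the 2 values shown sits), and the single measured step, an at least 1.3-fold higher number from compound 1 to compound 2 (0.12 log units; that floor lies within the scatter), ends at that limit. Compound 3 `O=c1cc(Cn2cc(CCc3ccccc3)nn2)c2ccc(O)cc2o1` carries phenyl in place of 2-hydroxyethyl on a saturated chain carbon, two bonds along the chain from an aromatic carbon. Among the compounds with values here, no measured step touches a phenyl or a 2-hydroxyethyl group, so the one step on record gives no guide to the size or direction of this change in this assay. Compound 3 is estimated at 70000 nM, with a range from 25000 nM to 200000 nM. The step expected is an at least 1.4-fold lower number from compound 2 to compound 3 (0.15 log units; that floor lies within the scatter), and a further limit-only result remains quite possible.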

Compound 3, half-maximal inhibitory concentration: > 100000 nM
Compound 3 was reported as a limit; the forecaster's own chance of this, stated with the estimate: 40%; middle value at least 1.4-fold (0.15 log units) from the limit.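

Phenyl at this place, on a saturated chain carbon two bonds along the chain from an aromatic carbon, also yields only a limit in this assay: compound 3 gives > 100000 nM. The step between the two limits cannot be read, and the comparison with the chloro compound gives an at least 1.3-fold higher number from compound 1 to compound 3 (0.12 log units; that floor lies within the scatter), so neither a gain nor a loss from phenyl is shown. The hydroxyl-bearing and the aromatic end groups thus both sit at the same ceiling: the limit of > 100000 nM in this assay, at which 2 of the 3 values shown sit.

On these data alone, whether an amine or a carboxylic acid at this place would give a readable value in this assay stays open. So does the effect of a longer chain carrying the phenyl.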